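Diethylamino for fluoro on the distal aryl ring

This account rests on a few compounds, and the source may have more. Where it says the series, first, only, none or still open, it means among the compounds named here.

Measured in a functional assay on the whole organism (integument) for inhibition, with Chilo suppressalis as the target, read by scintillation counting, with a stated time of 72 h; on this read-out lower numbers stand for stronger inhibition and higher numbers for weaker inhibition:
compound 1 `Cc1ccccc1C(=O)Nc1nnc(-c2ccc(Cl)cc2)s1` — 158 nM
compound 2 `CCOc1ccccc1C(=O)Nc1nnc(-c2ccc(Cl)cc2)s1` — > 5010 nM, a limit of this assay, not a number
compound 3 `COc1cccc(OC)c1C(=O)Nc1nnc(-c2ccc(F)cc2)s1` — 97.7 nM

Compound 3 and compound 1 lie within the scatter of each other in this assay; compound 2 sits at the limit (the limit of > 5010 nM in this assay, at which 1 of the 3 values shown sits).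

Compound 4 `CCN(CC)c1ccc(-c2nnc(NC(=O)c3c(OC)cccc3OC)s2)cc1` differs from compound 3 in one place: diethylamino in place of fluoro on an aromatic carbon. Within the data shown here, no measured step touches this ring. Among the measured compounds shown here, the only step known, an at least 31-fold higher number from compound 1 to compound 2 (1.50 log units; beyond the scatter), concerns a change on the other aryl ring and says nothing about the one changed here. No step beyond the scatter is therefore expected from compound 3 to compound 4, though the range must stay wide.

Compound 4 is expected at 150 nM, between 30 nM and 1500 nM, an expected step of a 1.5-fold higher number from compound 3 to compound 4 (0.19 log units; within the scatter).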

Compound 4, half-maximal inhibitory concentration: 741 nM
The estimate for compound 4 lay 4.9-fold (0.69 log units) below the measured number; low and high end bracket the measured number.
By their numbers in this assay, from the lowest: compounds 3 and 1 (each within the scatter of the next); then compound 4. At a limit, above all of these: compound 2.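

Among these compounds, this position on the aryl ring is not silent in this assay: diethylamino in place of fluoro gives a 7.6-fold higher number from compound 3 to compound 4 (0.88 log units; beyond the scatter), the first measured step at this ring. The change therefore costs inhibition, yet compound 4 still gives a measured number rather than a limit of the assay. No measurement at hand gives a reason for this step. Going by these compounds, whether the nitrogen or the ethyl chains carry the step stays open. A dimethylamino or a butyl group on this aromatic carbon would separate the two.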